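The source may report more compounds than this note shows. Statements on the series, on what has been measured and on what is new or still open speak of the compounds shown alone.

Measured compounds:
compound 1, `COc1ccccc1-c1nc(N)nc(N)n1`, 0.58
compound 2, `Nc1nc(N)nc(-c2cccc(C(F)(F)F)c2)n1`, 2.67

The two measured compounds share a core carrying a substituted phenyl ring. In a physicochemical assay for lipophilicity (a lower number here means a more polar compound, a higher number a more lipophilic compound), compound 1 gives 0.58, the lowest of the two numbers. Compound 2, which carries a trifluoromethyl group on the phenyl ring, gives 2.67 in this assay; the gap between compound 1 and compound 2 lies beyond the scatter, so compound 1 is the more polar of the pair. No single-point change connects these two compounds, so only their two values can be set side by side.

The third compound, compound 3, `Nc1nc(N)nc(-c2ccccc2[N+](=O)[O-])n1`, is not yet measured. It differs from compound 1 in one place: nitro in place of methoxy on an aromatic carbon. Nothing measured here tells how this exchange moves the reading, so the expectation for compound 3 rests on compound 1 alone. The step of a number 0.18 log units lower from compound 1 to compound 3 (within the scatter) is expected to be small, toward the polar side or none beyond the scatter. Compound 3 is therefore estimated at 0.4, with a range from -0.1 to 0.9.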

Compound 3, partition coefficient: 0.49
The estimate for compound 3 lay 0.09 log units below the measured number, within the range that was stated.
By their numbers in this assay, from the lowest: compounds 3 and 1 (each within the scatter of the next); then compound 2.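

Among these compounds, at this position, on an aromatic carbon of a six-membered aromatic ring of carbon only and ortho to a group of 8 heavy atoms, nitro in place of methoxy supplies the first single-place comparison. In this assay the reading shows a number 0.09 log units lower from compound 1 to compound 3 (within the scatter) for this exchange, so the two groups cannot be told apart by this measurement at this position, even though they differ in their atoms, in their hydrogen-bond acceptors and in the double bond that nitro brings. Nothing available explains why the two readings stand so close together.

What the compounds shown leave open is whether this closeness is particular to methoxy and nitro or extends to other groups on the same aromatic carbon, such as an amine, a carboxylic acid or a longer alkyl ether chain. From the compounds shown here alone, it also remains open whether the same exchange would read alike at another carbon of the ring, since compound 3 tests it at one place only.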